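The compounds below may be only part of what the source reports. "The series", "measured", "known", "first", "only" and "open" are said of these compounds alone.

Measured so far:
compound 1, `N=C(N)NCCC[C@H](NC(=O)CN(c1ncnc2c1ncn2C1CCCCO1)C1CC1)C(=O)OCc1ccccc1`: 19.6% in a functional assay on the whole organism (Tail, strain ICR) with Mus musculus as the target, in the tail flick test, with a stated time of 150 min, at a dose of 25 umol/kg by the oral route; a higher number here means a stronger effect of the compound at the dose given, a lower number a weaker effect
compound 2, `N=C(N)NCCC[C@H](NC(=O)CN(c1nc(Cl)nc2[nH]cnc12)C1CC1)C(=O)OCc1ccccc1`: 6.12% in this assay
compound 3, `NC(=O)CC[C@H](NC(=O)CN(c1ncnc2c1ncn2C1CCCCO1)C1CC1)C(=O)OCc1ccccc1`: 10.7% in this assay

Compound 3 stands second of the three numbers in this assay. Its nearest neighbour is compound 2, whose number is lower, and its furthest is compound 1, whose number is higher, but both gaps lie within the scatter, so no order among the three can be claimed.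

Compound 4, `CSCC[C@H](NC(=O)CN(c1ncnc2c1ncn2C1CCCCO1)C1CC1)C(=O)OCc1ccccc1`, has not yet been measured in this assay. It differs from compound 3 in one place: methylsulfanyl in place of carbamoyl on a saturated chain carbon, three bonds along the chain from an amide-type nitrogen and a carbonyl carbon.

Among the compounds with values here, only one measured step bears on this place, the exchange of side chain from compound 1 to compound 3, which gave a number 8.9 percentage points lower from compound 1 to compound 3 (within the scatter). Within the data shown here, that step is within the scatter, so the single comparison at this position shows no effect that rises above the noise. Among the measured compounds shown here, the change to compound 4 is a further exchange at the same carbon, and no measured step speaks for a large movement in either direction.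

Compound 4 is therefore expected to stay near compound 3, with an estimated step of a number 1.3 percentage points higher from compound 3 to compound 4 (within the scatter). The estimate for compound 4 in this assay is 12%, with a range from 2% to 25%.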

Compound 4, a percentage reported as activity, at one dose (the size of the read-out at that dose, not a potency): 17.5%
For compound 4 the middle estimate is 5.5 percentage points below the measured one, and the stated range covers the measured number.
By their numbers in this assay, from the lowest: compounds 2, 3, 4 and 1 (each within the scatter of the next, the first and the last beyond it).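

At the saturated chain carbon, three bonds along the chain from an amide-type nitrogen and a carbonyl carbon, methylsulfanyl in place of carbamoyl gives a number 6.8 percentage points higher from compound 3 to compound 4 (within the scatter) in this assay and the comparison with the side chain of compound 1 gives a number 2.1 percentage points lower from compound 1 to compound 4 (within the scatter) in the same test. This place has now been read with three different side chains on an otherwise shared structure, and every step among them stays within the scatter, so none of the three can be set above another. The exchange also replaces carbamoyl, which counts one hydrogen-bond donor, with a group that counts none, and the number stays within the scatter; no measurement at hand gives a reason for these numbers.

Going by these compounds, whether a carboxylic acid, a primary amine or a chain longer than 2-(methylsulfanyl)ethyl at this carbon would give a step beyond the scatter remains open. Also open, on these data alone, is whether these side chains would still read alike at another dose or time, since all three values come from a single dose and a single time point.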